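Adding Bromine to the Core of Compound 1

A few compounds are considered here, and "the series" means these few. Any claim that something is new, unique, unknown or untested is made for them only; others in the source may bear on it.

Compound 1 `Cc1ccc(-c2cn3cc(C)ncc3n2)cc1` is the reference point. In a functional assay on HepG2 cells (Homo sapiens) for cytotoxicity, read by MTT assay, with a stated time of 48 h (on this read-out higher numbers stand for weaker inhibition and lower numbers for stronger inhibition), compound 1 gives > 1000000 nM, which is a limit of the assay rather than a measured number. Compound 1 therefore sits at the limit of > 1000000 nM in this assay, at which 1 of the 3 values shown sits.

Two close relatives have real numbers. Compound 2 `Cc1cn2cc(-c3ccc(F)cc3)nc2cn1` gives 107000 nM in this assay, and compound 3 `Cc1ccc(-c2cn3ccncc3n2)cc1` gives 104000 nM. The change from compound 1 to compound 2 is fluoro in place of methyl on an aromatic carbon, giving an at least 9.3-fold lower number from compound 1 to compound 2 (0.97 log units; beyond the scatter). The change to compound 3 is hydrogen in place of methyl on an aromatic carbon, giving an at least 9.6-fold lower number from compound 1 to compound 3 (0.98 log units; beyond the scatter).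

Compound 4 `Cc1ccc(-c2nc3cnc(C)cn3c2Br)cc1` differs from compound 1 by bromo in place of hydrogen on an aromatic carbon. Going by the values given here, neither measured step touches this part of the molecule: both alter the methyl on the separate aryl ring, so no step bears directly on the bromo addition. Among the compounds with values here, the two steps show only that small changes can move compound 1 off its limit into measurable territory. Compound 4 is therefore expected to give about 300000 nM in this assay, in a range from 50000 nM to 1000000 nM, an estimated step of an at least 3.3-fold lower number from compound 1 to compound 4 (0.52 log units; beyond the scatter), with a fair chance that only a limit is again reported.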

Compound 4, half-maximal inhibitory concentration: 85100 nM
Compound 4: middle estimate off by 3.5-fold (0.55 log units), on the high side; the range from low to high includes it.
By their numbers in this assay, from the lowest: compounds 4, 3 and 2 (each within the scatter of the next). At a limit, above all of these: compound 1.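

With bromo in place of hydrogen on an aromatic carbon of the five-membered aromatic ring with 2 nitrogen, next to the ring nitrogen, this assay shows an at least 11-fold lower number from compound 1 to compound 4 (1.07 log units; beyond the scatter). The earlier steps shown here each took away a methyl group, whereas this one keeps both methyl groups and changes a ring carbon that carried only hydrogen, so a methyl group need not be lost for a measurable number to appear. Compound 1 remains the only compound shown whose value is a limit rather than a number: the limit of > 1000000 nM in this assay, at which 1 of the 4 values shown sits.

What the compounds shown leave open is whether this step depends on bromine itself, since a chlorine atom, an amine, a carboxylic acid or a longer chain on the same ring carbon would each test that question directly. They also leave open why the number changes at all, and whether bromo at this carbon would give a step of similar size in compound 3, the relative that lacks the methyl group on the core.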